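Chain extension on the amine in a cytotoxicity series

A few compounds are considered here, and "the series" means these few. Any claim that something is new, unique, unknown or untested is made for them only; others in the source may bear on it.

Compound 1 `CCCCNC1=CC(=O)C(C[C@]2(C)[C@@H](C)CC[C@]3(C)C(C)=CCC[C@@H]23)=CC1=O` carries a butyl chain on the amine nitrogen. In an ADME assay on HaCaT cells (Homo sapiens) for cytotoxicity, read by MTT assay, with a stated time of 72 h (on this read-out lower numbers stand for stronger inhibition and higher numbers for weaker inhibition), compound 1 gives > 100000 nM, which is a limit of the assay and not a number. Compound 3 `CCCCCCCCNC1=CC(=O)C(C[C@]2(C)[C@@H](C)CC[C@]3(C)C(C)=CCC[C@@H]23)=CC1=O` differs from compound 1 by butyl in place of hydrogen on a saturated chain carbon, four bonds along the chain from an amine nitrogen. In this assay compound 3 gives > 100000 nM, again a limit. The step that the two limits leave unreadable from compound 1 to compound 3 cannot be read because the limit of > 100000 nM in this assay, at which 3 of the 3 values shown sit, holds both of its ends. Compound 2 `CCCCNC1=CC(=O)C(C(C)(C)C)=CC1=O` has a different core; the difference between the two cores is not broken down here. In this assay compound 2 gives > 100000 nM, also a limit. Compound 4 `CCCCCCCCNC1=CC(=O)C(C(C)(C)C)=CC1=O` has not been measured; it differs from compound 2 by butyl in place of hydrogen on a saturated chain carbon, four bonds along the chain from an amine nitrogen, the same change as that from compound 1 to compound 3, at the same place. Going by the values given here, because the limit of > 100000 nM in this assay, at which 3 of the 3 values shown sit, gathers every value measured so far, compound 4 is expected to stay at the limit as well. The step of a number no higher from compound 2 to compound 4 (the limit leaves the size open) is accordingly expected to be near zero. Compound 4 is expected to give about 100000 nM in this assay, between 50000 nM and 300000 nM.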

Compound 4, half-maximal inhibitory concentration: > 100000 nM
Compound 4: no number, only a limit (the forecaster's own chance of this, stated with the estimate: 85%); the middle value sits exactly at the limit.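

Going by these compounds alone, compound 4, like compound 2, stands only as a limit in this assay and not as a number, so no step between them can be read, because every value shown sits at one limit: the limit of > 100000 nM in this assay, at which 4 of the 4 values shown sit.

The compounds shown leave open whether the longer chain or the difference between the two cores changes cytotoxicity at all.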